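Trifluorophenyl Variant Within a Series Sitting at the Assay Limit

This account rests on a few compounds, and the source may have more. Where it says the series, first, only, none or still open, it means among the compounds named here.

Compound 1, `OC[C@H]1O[C@@H](n2cnc3c(NCc4ccc(Cl)cc4)ncnc32)[C@H](O)[C@@H]1O`, is examined in a functional assay on B16 cells (Mus musculus) for antiproliferative activity, with a stated time of 72 h; on this read-out higher numbers stand for weaker inhibition and lower numbers for stronger inhibition. In this assay compound 1 gives > 166000 nM, which is a limit of the assay and not a number. Compound 2, `Cc1cccc(CNc2ncnc3c2ncn3[C@@H]2O[C@H](CO)[C@@H](O)[C@H]2O)c1`, gives > 166000 nM in this assay, again only a limit. Compound 3, `OC[C@H]1O[C@@H](n2cnc3c(NCc4ccc(F)cc4F)ncnc32)[C@H](O)[C@@H]1O`, gives > 166000 nM in this assay, once more a limit. Compound 1 thus stands no differently from its two neighbours; the limit of > 166000 nM in this assay, at which 3 of the 3 values shown sit, is all that the three values show. The steps a step that the two limits leave unreadable from compound 1 to compound 2 and a step that the two limits leave unreadable from compound 1 to compound 3 are accordingly unreadable, as is a step that the two limits leave unreadable from compound 2 to compound 3.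

Compound 4, `OC[C@H]1O[C@@H](n2cnc3c(NCc4ccc(F)c(F)c4F)ncnc32)[C@H](O)[C@@H]1O`, differs from compound 1 by 2,3,4-trifluorophenyl in place of 4-chlorophenyl on a saturated chain carbon bound to a nitrogen on an aromatic ring. The measured steps that bear on this change each exchange one substituted phenyl for another at the same place, and none gave a readable size. Compound 4 is therefore expected to sit at the same limit, and the step of a number no higher from compound 1 to compound 4 (the limit leaves the size open) is expected to be nothing beyond the scatter. The estimate for compound 4 is 166000 nM, with a range from 80000 nM to 500000 nM.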

Compound 4, half-maximal inhibitory concentration: > 166000 nM
Compound 4 was reported as a limit; the forecaster's own chance of this, stated with the estimate: 90%; the middle value sits exactly at the limit.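

No new step can be read between compound 4 and compound 1, compound 2 or compound 3, since each pair ends on a limit and not a number: the limit of > 166000 nM in this assay, at which 4 of the 4 values shown sit. The compounds shown leave open whether these four differ at all in inhibition, and which phenyl substituents, if any, would give a readable value.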